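The compounds below may be only part of what the source reports. "The series", "measured", "known", "first", "only" and "open" are said of these compounds alone.

Of the compounds shown here, three have been tested in a functional assay on the whole organism (strain Wistar Albino) for inhibition, with Rattus norvegicus as the target, read by paw edema, with a stated time of 2 h, at a dose of 20 mg/kg; on this read-out lower numbers stand for less inhibition and higher numbers for more inhibition at the one dose given (going by the name of the read-out). Compound 1 `COc1ccc2[nH]cc(Cc3nn4c(-c5ccoc5C)nnc4s3)c2c1` gives 20.1% in this assay. Compound 2 `COc1ccc(Cc2nnc3n2NC(c2ccco2)S3)cc1OC` gives 17.5%, and compound 3 `COc1ccc(Cl)c(-c2nnc3n2NC(c2ccc([N+](=O)[O-])o2)S3)c1` gives 18.5%. Compound 2 has the lowest of the three numbers, but its nearest neighbour, compound 3, lies within the usual scatter of it, and so does compound 1; the three readings are best seen as one cluster without a real order among them.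

The next compound, compound 4 `COc1ccc(Cc2nnc3n2NC(c2ccc[nH]2)S3)cc1OC`, differs from compound 2 in a single exchange on a saturated ring carbon of the fused ring system: 1H-pyrrol-2-yl in place of furan-2-yl on a saturated ring carbon. Going by the values given here, no pair of measured compounds shows the effect of such a change, so nothing can be read off directly. Given that compound 2 gives 17.5% and that all three measured numbers sit close together, the expected step from compound 2 to compound 4 is a number 1.5 percentage points higher from compound 2 to compound 4 (within the scatter), that is none beyond the scatter. Compound 4 is therefore expected to give 19%, within a range from 10% to 28%.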

Compound 4, a percentage reported as inhibition, in the whole organism at one dose (the size of the read-out at that dose, not a potency): 15.9%
Compound 4: middle estimate off by 3.1 percentage points, on the high side, and the stated range covers the measured number.
By their numbers in this assay, from the lowest: compounds 4, 2, 3 and 1 (each within the scatter of the next).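

Going by these compounds alone, this is the first exchange at the saturated ring carbon that can be read directly: in this assay, 1H-pyrrol-2-yl in place of furan-2-yl gives a number 1.6 percentage points lower from compound 2 to compound 4 (within the scatter). The exchange replaces one five-membered aromatic ring with another and, by the counts for the two groups, brings in a hydrogen-bond donor and removes a hydrogen-bond acceptor, yet the step stays within the scatter at this one dose. Nothing at hand explains this result.

On these data alone, both groups in this exchange are five-membered aromatic rings, so it remains open whether an amine, a carboxylic acid or a longer chain at this place would give a step beyond the scatter. Within the data shown here, with only this one pair, it is also open whether the same exchange would read alike on another core.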